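Adding a free amino group to the sulfonyl ethyl chain

The source may report more compounds than this note shows. Statements on the series, on what has been measured and on what is new or still open speak of the compounds shown alone.

Compound 1 `O=C(NS(=O)(=O)c1ccc(F)cc1)c1ccc(Nc2nc(NC3(c4ccc(Cl)cc4)CC3)nc(OCC(F)(F)F)n2)cc1`: 193 nm/s
Compound 2 `CC(C)(C)OC(=O)NCCS(=O)(=O)NC(=O)c1ccc(Nc2nc(NC3(c4ccc(Cl)cc4)CC3)nc(OCC(F)(F)F)n2)cc1`: 111 nm/s
Compound 3 `CCS(=O)(=O)NC(=O)c1ccc(Nc2nc(NC3(c4ccc(Cl)cc4)CC3)nc(OCC(F)(F)F)n2)cc1`: 28 nm/s

In a physicochemical assay for permeability, using PAMPA, at pH 7.4 (a higher number here means that the compound crosses the layer faster, a lower number that the compound crosses the layer more slowly), compound 3 stands lowest of the three: a 6.9-fold lower number from compound 1 to compound 3 (0.84 log units; beyond the scatter) and a 4.0-fold lower number from compound 2 to compound 3 (0.60 log units; beyond the scatter) both lie beyond the scatter. Compound 4 `NCCS(=O)(=O)NC(=O)c1ccc(Nc2nc(NC3(c4ccc(Cl)cc4)CC3)nc(OCC(F)(F)F)n2)cc1` differs from compound 3 by amino in place of hydrogen on a saturated chain carbon, two bonds along the chain from a sulfonyl sulfur. Among the compounds with values here, none of the measured steps puts an amino group in; the nearest is the step of a 4.0-fold lower number from compound 2 to compound 3 (0.60 log units; beyond the scatter), which removes the (tert-butoxycarbonyl)amino group from the same chain carbon, a different group. The reference point is the value of compound 3, 28 nm/s. Within the data shown here, with no direct precedent, the estimate for compound 4 is placed somewhat lower than that, with a wide range: compound 4 is expected to give 12 nm/s (range 3 nm/s to 40 nm/s), a step of a 2.3-fold lower number from compound 3 to compound 4 (0.37 log units; beyond the scatter).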

Compound 4, apparent permeability: 153 nm/s
Estimate against measurement, compound 4: 13-fold (1.11 log units) below; the measured number lies above the stated range.
By their numbers in this assay, from the lowest: compound 3; then compounds 2, 4 and 1 (each within the scatter of the next).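

In this assay, amino on a saturated chain carbon, two bonds along the chain from a sulfonyl sulfur, moves the number up rather than down (a 5.5-fold higher number from compound 3 to compound 4 (0.74 log units; beyond the scatter)). Removing tert-butoxycarbonyl from the amine nitrogen and exchanging 4-fluorophenyl for 2-aminoethyl both stay within the scatter (a 1.4-fold higher number from compound 2 to compound 4 (0.14 log units; within the scatter); a 1.3-fold lower number from compound 1 to compound 4 (0.10 log units; within the scatter)). No measurement shown here accounts for the step. Open, from the compounds shown here alone, is whether a longer chain carrying the amine would give a similar step, and whether a carboxylic acid on the same chain carbon would move the number the same way.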